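Swapping a (4-methylpiperazin-1-yl)methyl group for a diethylcarbamoyl group on the shared core

The source may hold more compounds than are shown below. What is called first, only, known or untested is meant among the compounds shown, and "the series" means these compounds.

Measured compounds:
compound 1, `CCN(CC)C/C1=C/C[C@](C)(CCC=C(C)C)/C=C/[C@@H](OC(=O)C=C(C)C)[C@](C)(O)/C=C/C1=O`, 570 nM
compound 2, `CC(C)=CCC[C@]1(C)/C=C/[C@@H](OC(=O)C=C(C)C)[C@](C)(O)/C=C/C(=O)/C(CN2CCN(C)CC2)=C\C1`, 2940 nM
compound 3, `CC(C)=CCC[C@]1(C)/C=C/[C@@H](OC(=O)C=C(C)C)[C@](C)(O)/C=C/C(=O)/C(COC(=O)c2ccc([N+](=O)[O-])cc2)=C\C1`, 2560 nM

In a functional assay on SMMC-7721 cells (Homo sapiens) for antiproliferative activity, read by MTT assay, with a stated time of 48 h (a lower number here means a stronger inhibitor, a higher number a weaker inhibitor), compound 2 gives the highest number of the three, so it is the weakest inhibitor measured here. Compound 4 is `CCN(CC)C(=O)/C1=C/C[C@](C)(CCC=C(C)C)/C=C/[C@@H](OC(=O)C=C(C)C)[C@](C)(O)/C=C/C1=O`. Its change from compound 2 is diethylcarbamoyl in place of (4-methylpiperazin-1-yl)methyl on a double-bonded ring carbon. The closest guide is the step of a 5.2-fold higher number from compound 1 to compound 2 (0.71 log units; beyond the scatter), where a diethylamino group gave a clearly lower number than the piperazine. Compound 3 shows that a carbonyl-bearing group sits close to compound 2, as seen in a 1.1-fold lower number from compound 2 to compound 3 (0.06 log units; within the scatter). For the measured compounds named here, no measured compound carries an amide directly on the ring, so the picture is uncertain. A modest drop toward compound 1 is expected, giving a 1.5-fold lower number from compound 2 to compound 4 (0.17 log units; within the scatter). Compound 4 is estimated at 2000 nM, with a range from 700 nM to 6000 nM.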

Compound 4, half-maximal inhibitory concentration: 13800 nM
For compound 4 the middle estimate is 6.9-fold (0.84 log units) below the measured one; measured number outside the range, above it.
By their numbers in this assay, from the lowest: compound 1; then compounds 3 and 2 (each within the scatter of the next); then compound 4.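

In this assay, replacing (diethylamino)methyl with diethylcarbamoyl keeps the diethyl-substituted nitrogen but turns the saturated chain carbon into a carbonyl, and this gives a 24-fold higher number from compound 1 to compound 4 (1.38 log units; beyond the scatter) on the double-bonded ring carbon. For the compounds shown here, this shows that the link to the ring matters here, not only the amine group, and the step is larger than any among the earlier compounds. Compound 4 also sits apart from the piperazine, with a 4.7-fold higher number from compound 2 to compound 4 (0.67 log units; beyond the scatter) and no data here explain the loss. Still open, going by these compounds, is whether a (dimethylamino)methyl or (pyrrolidin-1-yl)methyl group would match the (diethylamino)methyl group at this position.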